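A few compounds are considered here, and "the series" means these few. Any claim that something is new, unique, unknown or untested is made for them only; others in the source may bear on it.

Compound 3 `C=CC(=O)Nc1cc(Nc2nccc(-c3cn(C)c4ccc(F)cc34)n2)c(OC)cc1N(C)CCN(C)C` belongs to a small set of anilinopyrimidine amides that share one core and differ in the group attached to the amide carbonyl. In a functional assay on A549 cells (Homo sapiens) for antiproliferative activity, read by MTT assay, with a stated time of 72 h (a lower number here means a stronger inhibitor, a higher number a weaker inhibitor), compound 3 gives 329 nM, the lowest of the three measured numbers. Compound 1 `C/C=C\C(=O)Nc1cc(Nc2nccc(-c3cn(C)c4ccccc34)n2)c(OC)cc1N(C)CCN(C)C` gives 660 nM, a gap to compound 3 that lies within the scatter; compound 2 `COc1cc(N(C)CCN(C)C)c(NC(=O)C=C(C)C)cc1Nc1nccc(-c2cn(C)c3ccccc23)n1` gives 4100 nM, clearly beyond it. Compound 1 and compound 3 differ in two places at once, so their two values alone say nothing about either change by itself.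

Compound 4 `COc1cc(N(C)CCN(C)C)c(NC(=O)/C=C\C(C)C)cc1Nc1nccc(-c2cn(C)c3ccc(F)cc23)n1` is compound 3 with 3-methylbut-1-en-1-yl in place of vinyl on a carbonyl carbon. Among the compounds with values here, only one measured step touches the same place: a 6.2-fold higher number from compound 1 to compound 2 (0.79 log units; beyond the scatter), where the group on the carbonyl carbon also grew larger and the number rose. Within the data shown here, the present change adds more to that carbon than that step did, and there is no example in which such growth left the number unchanged or lowered it. Compound 4 is therefore expected to show a higher number than compound 3, with the step of a 5.5-fold higher number from compound 3 to compound 4 (0.74 log units; beyond the scatter) estimated as modest to sizeable and beyond the scatter. Compound 4 is estimated at 1800 nM, within a range of 500 nM to 6000 nM.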

Compound 4, half-maximal inhibitory concentration: 6140 nM
Beside the measured number, compound 4's estimate is 3.4-fold (0.53 log units) below it; measured number above the stated range.
By their numbers in this assay, from the lowest: compounds 3 and 1 (each within the scatter of the next); then compounds 2 and 4 (each within the scatter of the next).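

In this assay, replacing vinyl with 3-methylbut-1-en-1-yl on a carbonyl carbon whose other neighbour is an amide-type nitrogen gives a 19-fold higher number from compound 3 to compound 4 (1.27 log units; beyond the scatter) and counts as a large step. Together with a 6.2-fold higher number from compound 1 to compound 2 (0.79 log units; beyond the scatter), which counts as a modest step, this gives a second case, from a different starting compound and with a different entering group, in which a larger group at this place goes with a higher number, and no listed step at this place goes against it. Nothing available here bears on why the number rises at this place.

The two steps differ in both starting compound and entering group, so they cannot show how much of the difference in their size belongs to the group and how much to the rest of the molecule. From the compounds shown here alone, it remains open whether the same change would act alike on the core of compound 1, and whether a cyclopropyl group, an ethynyl group or a chain ending in a dimethylamino amine on this carbonyl carbon would also raise the number.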